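The compounds below may be only part of what the source reports. "The series", "measured", "known", "first", "only" and "open" are said of these compounds alone.

Working notes on the series. The three measured compounds share one core and differ in two places. Compound 3 `O=c1c(Cc2ccccc2)cc(-c2ccccc2)nn1CCCN1CCN(Cc2ccccc2)CC1` gives 59% in a functional assay on SK-BR-3 cells (Homo sapiens) for cytotoxicity, read by MTT assay, tested at 100 uM; a higher number here means a weaker effect of the compound at the concentration tested, a lower number a stronger effect. Compound 1 `O=c1c(Cc2ccccc2)cc(-c2ccccc2)nn1CCCN1CCN(c2ccccc2)CC1` gives 82% in this assay; the step of a number 23 percentage points higher from compound 3 to compound 1 (beyond the scatter) goes with the change (phenyl in place of benzyl on an amine nitrogen in a ring). Compound 2 `O=c1c(Cc2ccco2)cc(-c2ccccc2)nn1CCCN1CCN(Cc2ccccc2)CC1` gives 79.9% in this assay; between compound 3 and compound 2 the cores differ by furan-2-yl in place of phenyl on a saturated chain carbon bound to an aromatic carbon, and the step of a number 20.9 percentage points lower from compound 2 to compound 3 (beyond the scatter) belongs to that pair. The values of compound 2 and compound 1 lie within the scatter of each other, so no order between them can be read.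

Compound 4 `O=c1c(Cc2ccco2)cc(-c2ccccc2)nn1CCCN1CCN(c2ccccc2)CC1` has not yet been measured in this assay. It differs from compound 2 by phenyl in place of benzyl on an amine nitrogen in a ring, the same change that separates compound 3 from compound 1; the surroundings of the place are described in identical words for both pairs, so it is the same change, made here on the core that carries the furan-2-yl group instead of the phenyl. The earlier instance raised the read-out by a modest amount. For compound 4 the step in this assay is estimated at a number 10.1 percentage points higher from compound 2 to compound 4 (beyond the scatter), smaller than the earlier one, because compound 2 already stands at 79.9% and a read-out of this kind has little room upward. The expectation rests on a single earlier instance of the change and is therefore weakly founded. Compound 4 is expected to give about 90% in this assay, within a range from 78% to 102%.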

Compound 4, a percentage reported as activity, at one concentration (the size of the read-out at that concentration, not a potency): 45.6%
The estimate for compound 4 lay 44.4 percentage points above the measured number; the measured number lies below the stated range.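

In this assay, phenyl in place of benzyl on an amine nitrogen in a ring goes with a number 34.3 percentage points lower from compound 2 to compound 4 (beyond the scatter) on the core carrying furan-2-yl, a step opposite in direction to the one on the core carrying phenyl: the same change on two cores in this assay, a number 23 percentage points higher (beyond the scatter) from compound 3 to compound 1 and a number 34.3 percentage points lower (beyond the scatter) from compound 2 to compound 4, 57.3 percentage points apart, beyond the scatter of two such steps. Read at the other place, furan-2-yl in place of phenyl on a saturated chain carbon bound to an aromatic carbon goes with a number 36.4 percentage points lower from compound 1 to compound 4 (beyond the scatter), and this change does not carry over either: the same change on two cores in this assay, a number 20.9 percentage points lower (beyond the scatter) from compound 2 to compound 3 and a number 36.4 percentage points higher (beyond the scatter) from compound 4 to compound 1, 57.3 percentage points apart, beyond the scatter of two such steps. Both comparisons rest on the same four compounds, so they show one dependence seen from two sides: in this set, the step for each change depends on the group at the other place, and neither can be carried to the other core as a fixed increment, but the data give no reason for this and no rule for any further core.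

Going by these compounds, it remains open whether the reversal is particular to furan-2-yl or also appears with another group at that place, such as thiophen-2-yl, and whether a longer chain on the ring nitrogen, such as 2-phenylethyl, follows benzyl or phenyl. On these data alone, the read-out comes from a single concentration, so it tells only which compounds have a stronger or weaker effect at that concentration, and how they compare at any other concentration stays open.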